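Swapping cyclopropyl for propyl on an aromatic nitrogen

This account rests on a few compounds, and the source may have more. Where it says the series, first, only, none or still open, it means among the compounds named here.

Of the compounds shown here, three built on a shared core have been measured in a physicochemical assay for solubility, measured as kinetic solubility, at pH 7.4 (on this read-out lower numbers stand for lower solubility and higher numbers for higher solubility), so far. Compound 1 (`Cc1cccc(C(=O)N[C@@H]2C(=O)Nc3c(c(C)nn3C3CCCC3)[C@@H]2c2ccc(F)cc2)c1`) reads 17100 nM and compound 3 (`Cc1ccc([C@H]2c3c(C)nn(-c4ccccc4)c3NC(=O)[C@H]2NC(=O)c2cccc(C)c2)cc1`) reads 1100 nM on this scale. Compound 2 (`CCN1C(=O)[C@@H](NC(=O)c2cccc(C)c2)[C@@H](c2ccc(F)cc2)c2c(C)nn(C3CC3)c21`) stands highest of the three at 46100 nM on the same scale, clearly apart from both others.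

Compound 4 (`CCCn1nc(C)c2c1N(CC)C(=O)[C@@H](NC(=O)c1cccc(C)c1)[C@H]2c1ccc(F)cc1`) has not been measured yet. It differs from compound 2 in one place, with propyl in place of cyclopropyl on an aromatic nitrogen. Going by the values given here, the measured compounds differ from one another in more than one place, so no measured pair shows this change on its own, and any expectation here is rough. A small downward move is expected (a 1.4-fold lower number from compound 2 to compound 4 (0.16 log units; within the scatter)) and is estimated to stay within the usual scatter of repeated measurements. In this assay the expected value for compound 4 is 32000 nM (estimated range 13000 nM to 70000 nM).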

Compound 4, solubility: 10900 nM
Estimate against measurement, compound 4: 2.9-fold (0.47 log units) above, outside the stated range (below it).
By their numbers in this assay, from the lowest: compound 3; then compounds 4 and 1 (each within the scatter of the next); then compound 2.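

In this assay, going by these compounds alone, putting propyl in place of cyclopropyl on this aromatic nitrogen gives a 4.2-fold lower number from compound 2 to compound 4 (0.63 log units; beyond the scatter), the first step here that isolates a single change. The position is therefore not indifferent to the swap: both groups have 3 heavy atoms, all carbon, with no hydrogen-bond donors or acceptors, and the visible difference is that cyclopropyl is a ring and propyl is not, yet the step lies beyond the usual scatter. Nothing available explains why the number moves.

A single pair cannot show whether the same swap would give a similar step with other groups elsewhere on the shared core. The compounds shown also leave open how a longer chain, or a propyl chain carrying an amine, would read on this nitrogen in this assay.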